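The source may hold more compounds than are shown below. What is called first, only, known or untested is meant among the compounds shown, and "the series" means these compounds.

Measured so far:
compound 1, `COc1ccc(-c2nc(CN(C)C)sc2-c2ccc(OC)cc2)cc1`: 8.4 uM
compound 2, `COc1ccc(-c2nc(CNC(=O)CSc3ccccc3)sc2-c2ccc(OC)cc2)cc1`: 4.2 uM

Both compounds were tested in a functional assay (aorta) with Rattus norvegicus as the target; a lower number here means that less compound is needed, a higher number that more compound is needed for the effect. Compound 1 stands at the highest of the two numbers; its nearest neighbour is compound 2, and the step of a 2.0-fold lower number from compound 1 to compound 2 (0.30 log units; within the scatter) lies within the scatter, so the two cannot be told apart on these data.

Compound 3, `COc1ccc(-c2nc(C(=O)N=C(N)N)sc2-c2ccc(OC)cc2)cc1`, has not yet been measured. It differs from compound 1 in one place: a group of 6 heavy atoms (2 carbon, 3 nitrogen, 1 oxygen; no ring) in place of a group of 4 heavy atoms (3 carbon, 1 nitrogen; no ring), on an aromatic carbon. Among the compounds with values here, the only measured step that touches the same part of the shared core is the one from compound 1 to compound 2, and that step stayed within the scatter. Within the data shown here, the group entering compound 3 is, however, not the one entering compound 2, so this single step is a weak guide. The expectation is therefore a step of about a 1.1-fold lower number from compound 1 to compound 3 (0.02 log units; within the scatter) in this assay, that is, nothing beyond the scatter, with a wide range to allow for the unknown. Compound 3 is estimated at 8 uM, between 2 uM and 40 uM.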

Compound 3, concentration for half-maximal effect: > 100 uM
Compound 3 gave a limit, no number (the forecaster's own chance of this, stated with the estimate: 20%); at least 12-fold (1.09 log units) between middle value and limit.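

In this assay compound 3 gives > 100 uM, which is a limit of the assay and not a number. With an at least 11-fold higher number from compound 1 to compound 3 (1.07 log units; beyond the scatter), the result shows that what sits on this aromatic carbon, next to the ring nitrogen and next to the ring sulfur, can matter a great deal, which the earlier change could not show: with a 2.0-fold lower number from compound 1 to compound 2 (0.30 log units; within the scatter), the saturated chain carbon stayed in place, whereas here the whole (dimethylamino)methyl leaves and the new group sits directly on the aromatic carbon. The true size of the new step stays unknown, and it can only be read as a lower bound: the limit of > 100 uM in this assay, at which 1 of the 3 values shown sits.

Since the leaving and entering groups differ in several features at once, the compounds shown leave open whether the step follows from losing the saturated chain carbon, from the carbonyl on the aromatic carbon, or from the nitrogen-rich end of the new group. A plain primary amide, a carboxylic acid or an aminomethyl group on the same aromatic carbon would help to separate these possibilities.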